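This account rests on a few compounds, and the source may have more. Where it says the series, first, only, none or still open, it means among the compounds named here.

Two hydroxamic acids sharing one core open the account: compound 1 `C#CCN(C)Cc1cccc(NC(=O)CCCC(=O)NO)c1` and compound 2 `C#CCN(C)Cc1ccc(NC(=O)CCC(=O)NO)cc1`. In a functional assay on DU-145 cells (Homo sapiens) for inhibition, read by MTT assay, with a stated time of 48 h (on this read-out lower numbers stand for stronger inhibition of growth and higher numbers for weaker inhibition of growth), compound 1 gives > 10000 nM, which is a limit of the assay and not a number. Compound 2 in this assay gives > 10000 nM, again a limit, so compound 2 stands at the limit, as does every value shown (the limit of > 10000 nM in this assay, at which 2 of the 2 values shown sit). Compound 3 `C#CCN(C)Cc1ccc(NC(=O)CCCCCCC(=O)NO)cc1` differs from compound 2 by 4-(hydroxycarbamoyl)butyl in place of hydroxycarbamoyl on a saturated chain carbon, two bonds along the chain from a carbonyl carbon. Among the compounds with values here, no measured step exists here; the account expects the 4-(hydroxycarbamoyl)butyl chain to carry compound 3 into the measurable range, a step of an at least 3.3-fold lower number from compound 2 to compound 3 (0.52 log units; beyond the scatter). Compound 3 is therefore estimated at 3000 nM, within 800 nM to 10000 nM.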

Compound 3, concentration for 50% growth inhibition: 1510 nM
Compound 3: middle estimate off by 2.0-fold (0.30 log units), on the high side; measured number inside the range.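

In this assay, putting 4-(hydroxycarbamoyl)butyl in place of hydroxycarbamoyl at this saturated chain carbon brings the series its first number that is not a limit, with an at least 6.6-fold lower number from compound 2 to compound 3 (0.82 log units; beyond the scatter) in this chain. Compound 2 stands at a limit of the assay, so this step gives only a floor for the size of the change, and compound 3 alone has left that limit: the limit of > 10000 nM in this assay, at which 2 of the 3 values shown sit.

From the compounds shown here alone, whether a longer chain would lower the number further remains open, as does the effect of a carboxylic acid in place of the terminal hydroxycarbamoyl.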